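A few compounds are considered here, and "the series" means these few. Any claim that something is new, unique, unknown or untested is made for them only; others in the source may bear on it.

In an ADME assay on HEL cells (Homo sapiens) for cytotoxicity (on this read-out higher numbers stand for lower toxicity in this test and lower numbers for higher toxicity in this test), three compounds built on one shared core have been measured. Compound 1 `COc1cc(NC(C)CCCNC(=O)NCc2ccncc2)c2ncccc2c1` gives 72000 nM. Compound 2 `COc1cc(NC(C)CCCNC(=O)NCc2ccccc2)c2ncccc2c1` gives 66000 nM, and compound 3 `COc1cc(NC(C)CCCNC(=O)N(C2CCCCC2)C2CCCCC2)c2ncccc2c1` gives 27000 nM. Compound 2 thus holds the second highest of the three numbers: the step of a 1.1-fold lower number from compound 1 to compound 2 (0.04 log units; within the scatter) lies within the scatter, while the values of compound 2 and compound 3 show compound 3 with a lower number, beyond the scatter.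

Compound 4 `COc1cc(NC(C)CCCNC(=O)n2nnc3ccccc32)c2ncccc2c1` differs from compound 2 in one place: a group of 9 heavy atoms (6 carbon, 3 nitrogen; one five-membered aromatic ring with 3 hetero atoms, one six-membered aromatic ring of carbon only) in place of a group of 8 heavy atoms (7 carbon, 1 nitrogen; one six-membered aromatic ring of carbon only), on a carbonyl carbon. Going by the values given here, the only measured step that touches the same group, a 1.1-fold lower number from compound 1 to compound 2 (0.04 log units; within the scatter), put phenyl in place of pyridin-4-yl and stayed within the scatter; no measured step replaces the whole benzylamino group as this change does. The expectation in this assay is a small step at most, leaning toward a somewhat lower number. Compound 4 is estimated at 50000 nM, within a range from 20000 nM to 120000 nM, which corresponds to an expected step of a 1.3-fold lower number from compound 2 to compound 4 (0.12 log units; within the scatter).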

Compound 4, half-maximal cytotoxic concentration: 72000 nM
Beside the measured number, compound 4's estimate is 1.4-fold (0.16 log units) below it, within the range that was stated.
By their numbers in this assay, from the lowest: compound 3; then compounds 2, 1 and 4 (each within the scatter of the next).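

In this assay, the step away from benzylamino on the carbonyl carbon gives a 1.1-fold higher number from compound 2 to compound 4 (0.04 log units; within the scatter), and the step away from the pyridine-bearing group gives no change at the digits printed from compound 1 to compound 4 (within the scatter). Earlier, only the aromatic ring at the end of this group had been exchanged; here the whole group goes, including the hydrogen-bond donor of benzylamino, and the new group, with 0 hydrogen-bond donors and 3 hydrogen-bond acceptors, still leaves the number within the scatter. Nothing on hand explains why the number holds at this place.

Going by these compounds, it stays open whether a small group on the carbonyl carbon, such as dimethylamino, would also leave the number in place. On these data alone, a carboxylic acid on the aromatic ring of benzylamino remains equally open.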